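The source may hold more compounds than are shown below. What is called first, only, known or untested is meant among the compounds shown, and "the series" means these compounds.

Of the compounds shown here, three of one shared core have been measured in a functional assay on HeLa cells (Homo sapiens) for cytotoxicity, read by MTT assay, with a stated time of 48 h; a lower number here means a stronger inhibitor, a higher number a weaker inhibitor. Compound 1 `COc1ccc(-c2cc(C(=O)Nc3nc4ccc(Cl)cc4s3)nc3cc(-c4ccccc4)nn23)cc1` gives 5880 nM. Compound 2 `COc1ccc(-c2cc(C(=O)Nc3nc4ccc(Cl)cc4s3)nc3cc(-c4ccccc4)nn23)cc1OC` gives 9120 nM, and compound 3 `COc1ccc(-c2cc(C(=O)Nc3nc4ccc(OC)cc4s3)nc3cc(-c4ccccc4)nn23)cc1` gives 24500 nM. The step of a 1.6-fold lower number from compound 2 to compound 1 (0.19 log units; within the scatter) is the change (hydrogen in place of methoxy on an aromatic carbon). The step of a 4.2-fold higher number from compound 1 to compound 3 (0.62 log units; beyond the scatter) follows the change of methoxy in place of chloro on an aromatic carbon. The difference between the cores of compound 2 and compound 3 is not broken down here.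

Compound 4 `COc1ccc(-c2cc(C(=O)Nc3nc4ccccc4s3)nc3cc(-c4ccccc4)nn23)cc1` is not yet measured in this assay. It differs from compound 3 by hydrogen in place of methoxy on an aromatic carbon. This is the same kind of change as that from compound 2 to compound 1, but the place differs: there the carbon sat ortho to a methoxy group and meta to a large group, here it sits in a fused or bridged system of two rings, meta and para to a fused ring. Given the earlier step of a 1.6-fold lower number from compound 2 to compound 1 (0.19 log units; within the scatter) stayed within the scatter, a small step of a 1.4-fold lower number from compound 3 to compound 4 (0.13 log units; within the scatter) is expected. Compound 4 is estimated at 18000 nM, between 7000 nM and 45000 nM.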

Compound 4, half-maximal inhibitory concentration: 4670 nM
Beside the measured number, compound 4's estimate is 3.9-fold (0.59 log units) above it; measured number outside the range, below it.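

Hydrogen in place of methoxy does not carry over as one fixed step in this assay: on the 6-methoxy-1,3-benzothiazol-2-yl group it gives a 5.2-fold lower number from compound 3 to compound 4 (0.72 log units; beyond the scatter), and the comparison with the earlier step reads: the same change on two cores in this assay, a 1.6-fold lower number (0.19 log units; within the scatter) from compound 2 to compound 1 and a 5.2-fold lower number (0.72 log units; beyond the scatter) from compound 3 to compound 4, 3.4-fold (0.53 log units) apart, beyond the scatter of two such steps

At the same place, hydrogen in place of chloro gives a 1.3-fold lower number from compound 1 to compound 4 (0.10 log units; within the scatter), so compound 1 and compound 4 cannot be told apart here, while compound 3 with its methoxy group stands apart from both. The two methoxy removals differ in place as well as in surroundings, and with a single pair for each, the data do not show whether the place or the rest of the molecule sets the size of the step, nor do they give a cause.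

Open, on these data alone, is whether an amine, a carboxylic acid or an ethoxy group on that aromatic carbon would stay level with hydrogen and chloro or follow methoxy. Also open, as far as these compounds go, is whether removing the methoxy group from the same place on a second core would repeat the larger step.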